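Anilinoquinazoline sulfonamides: aryl swap at the amine

The source may report more compounds than this note shows. Statements on the series, on what has been measured and on what is new or still open speak of the compounds shown alone.

Measured compounds:
compound 1, `COc1cc2ncnc(Nc3ccc(F)cc3)c2cc1OCCCCC(=O)Nc1ccc(S(N)(=O)=O)cc1`, > 40000 nM
compound 2, `COc1cc2ncnc(Nc3cccc(Cl)c3F)c2cc1OCCCCC(=O)Nc1ccc(S(N)(=O)=O)cc1`, 10500 nM

Among the measured compounds shown here, in a functional assay on A549 cells (Homo sapiens) for antiproliferative activity, read by MTT assay, with a stated time of 72 h (a higher number here means a weaker inhibitor, a lower number a stronger inhibitor), compound 2 gives 10500 nM, the only number among the two values shown. For compound 1 this assay reports only a limit, > 40000 nM. For the measured compounds named here, the one measured step, an at least 3.8-fold lower number from compound 1 to compound 2 (0.58 log units; beyond the scatter), is bounded on one side by the limit of > 40000 nM in this assay, at which 1 of the 2 values shown sits, so its true size is known only as a minimum.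

Compound 3, `COc1cc2ncnc(Nc3ccc(C)cc3)c2cc1OCCCCC(=O)Nc1ccc(S(N)(=O)=O)cc1`, has not been measured in this assay. It differs from compound 2 by 4-methylphenyl in place of 3-chloro-2-fluorophenyl on a nitrogen on an aromatic ring. The step from compound 1 to compound 2 bears on this change only in part: it replaced a 4-fluorophenyl with the 3-chloro-2-fluorophenyl that compound 3 now gives up, and it came with a lower number. Compound 3 returns to a group substituted in the same position as the 4-fluorophenyl of compound 1, though with a methyl rather than a fluorine. The expectation for compound 3 is therefore a step back toward a higher number, a 2.9-fold higher number from compound 2 to compound 3 (0.46 log units; beyond the scatter), with a real chance that this assay again reports only a limit. Compound 3 is estimated at 30000 nM, within a range from 8000 nM to 100000 nM.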

Compound 3, half-maximal inhibitory concentration: > 40000 nM
Compound 3: a limit, no number (the forecaster's own chance of this, stated with the estimate: 45%); at least 1.3-fold (0.12 log units) between middle value and limit.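

In this assay, replacing the 3-chloro-2-fluorophenyl of compound 2 with 4-methylphenyl gives an at least 3.8-fold higher number from compound 2 to compound 3 (0.58 log units; beyond the scatter), so a second group on this nitrogen also loses the measurable activity seen with the 3-chloro-2-fluorophenyl. Among the compounds shown, only compound 2 gives a number, 10500 nM, and its steps to both of the others are beyond the scatter, so it is the strongest of the three. Compound 1 and compound 3 differ by methyl in place of fluoro on an aromatic carbon, but the step between them cannot be read, and neither compound can be ranked against the other: the limit of > 40000 nM in this assay, at which 2 of the 3 values shown sit.

The compounds shown leave open whether the gain in compound 2 needs both halogens, since a phenyl carrying chlorine alone or fluorine alone would separate the two. Also open, as far as these compounds go, is whether an unsubstituted phenyl on this nitrogen, or a longer chain between the core and the amide, would bring a number well below that of compound 2.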